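The source may report more compounds than this note shows. Statements on the series, on what has been measured and on what is new or still open speak of the compounds shown alone.

Compound 1 `CN1CC2(CCN(C(=O)Nc3cc(F)cc(F)c3)CC2)C1c1ccc(Cl)cc1` gives 214 nM in an assay on HEK293 cells for inhibition of Voltage-dependent T-type calcium channel subunit alpha-1H (Homo sapiens), read by patch clamp, using a membrane potential dye; a higher number here means a weaker inhibitor, a lower number a stronger inhibitor. Compound 2 `CC(C)N1CC2(CCN(C(=O)Nc3cc(F)cc(F)c3)CC2)C1c1ccc(F)cc1` gives 172 nM in this assay.

Compound 2 has the lower of the two numbers, but its nearest neighbour, compound 1, lies within the scatter of it, so the two cannot be told apart. Compound 3 `CN1CC2(CCN(C(=O)Nc3cc(F)cc(F)c3)CC2)C1c1ccc(F)cc1` differs from compound 2 by methyl in place of isopropyl on an amine nitrogen in a ring. Among the compounds with values here, no measured pair shows this exact change, so its effect is open; compound 1 and compound 2, which differ in two places, sit within the scatter of each other. Compound 3 is therefore expected at 200 nM, between 90 nM and 450 nM, an expected step of a 1.2-fold higher number from compound 2 to compound 3 (0.07 log units; within the scatter) not beyond the scatter.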

Compound 3, half-maximal inhibitory concentration: 410 nM
The estimate for compound 3 lay 2.1-fold (0.31 log units) below the measured number; the measured number falls inside the stated range.
By their numbers in this assay, from the lowest: compounds 2, 1 and 3 (each within the scatter of the next, the first and the last beyond it).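

In this assay, the group on the amine nitrogen in the four-membered ring turns out to matter: methyl in place of isopropyl gives a 2.4-fold higher number from compound 2 to compound 3 (0.38 log units; beyond the scatter), a modest step. Fluoro in place of chloro on the aromatic carbon gives a 1.9-fold higher number from compound 1 to compound 3 (0.28 log units; within the scatter), so that exchange has no readable effect. Nothing measured here explains the step at the nitrogen.

On these data alone, whether an ethyl, a cyclopropyl or a longer chain on this nitrogen would match isopropyl remains open. Also open, as far as these compounds go, is whether the same step would appear with chloro on the aromatic ring.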